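Three limits and one propylamino analogue

The compounds below may be only part of what the source reports. "The series", "measured", "known", "first", "only" and "open" are said of these compounds alone.

compound 1 `CN(C)c1nc(N)nc2c1ncn2/C=C1/CC1(CO)CO` gives > 24000 nM (a limit)
compound 2 `CCCSc1nc(N)nc2c1ncn2/C=C1/CC1(CO)CO` gives > 20000 nM (a limit)
compound 3 `Nc1nc(NCc2ccccc2)c2ncn(/C=C3/CC3(CO)CO)c2n1` gives > 24000 nM (a limit)

In an ADME assay on Akata cells (Homo sapiens) for cytotoxicity, with a stated time of 7 days (a higher number here means that more compound is tolerated, a lower number that less compound is tolerated), compound 3 gives > 24000 nM as a limit and not a number. Among the measured compounds shown here, compound 1 and compound 2 also end in limits, so no measured compound has a readable value. Compound 4 `CCCNc1nc(N)nc2c1ncn2/C=C1/CC1(CO)CO` differs from compound 3 by ethyl in place of phenyl on a saturated chain carbon bound to a nitrogen on an aromatic ring. For the measured compounds named here, the steps that bear on this, a step that the two limits leave unreadable from compound 1 to compound 3 and a step that the two limits leave unreadable from compound 2 to compound 3 and a step that the two limits leave unreadable from compound 1 to compound 2 (none with a size to carry over), leave no ground for a real shift, so in this assay no step beyond the scatter is expected, and another limit is likely. The expected change is a number no higher from compound 3 to compound 4 (the limit leaves the size open) (an estimate). Compound 4 is estimated at 24000 nM (range 12000 nM to 48000 nM).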

Compound 4, half-maximal cytotoxic concentration: > 24000 nM
Compound 4 was reported as a limit (the forecaster's own chance of this, stated with the estimate: 85%); the middle value sits exactly at the limit.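

Among the compounds shown here, compound 1, compound 2, compound 3 and compound 4 all end in limits, so no step among them can be read. The compounds shown leave open whether any of these groups changes the tolerated concentration in this assay.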